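The compounds below may be only part of what the source reports. "The series", "measured", "known", "first", "only" and "open" are said of these compounds alone.

Compound 1 `Nc1nc2cc(-c3nn(CCCC(=O)NO)c4ncnc(N)c34)ccc2o1`: > 50000 nM
Compound 2 `Nc1nc2cc(-c3nn(CCC(=O)NO)c4ncnc(N)c34)ccc2o1`: > 150000 nM
Compound 3 `Nc1nc2cc(-c3nn(CCCCC(=O)NO)c4ncnc(N)c34)ccc2o1`: > 50000 nM

All three were tested in a functional assay on CNE-2 cells (Homo sapiens) for inhibition, read by MTT assay, with a stated time of 72 h (on this read-out lower numbers stand for stronger inhibition and higher numbers for weaker inhibition), and each value is a limit, not a number. Compound 3 stands at > 50000 nM, which is a limit. Compound 4 `Nc1nc2cc(-c3nn(CCCCCC(=O)NO)c4ncnc(N)c34)ccc2o1` extends its chain, with (hydroxycarbamoyl)methyl in place of hydroxycarbamoyl on a saturated chain carbon, four bonds along the chain from an aromatic nitrogen. The same exchange, three bonds along the chain from an aromatic nitrogen, gave a step that the two limits leave unreadable from compound 1 to compound 3. The longer change gave a step that the two limits leave unreadable from compound 2 to compound 3, and the remaining comparison gave a step that the two limits leave unreadable from compound 1 to compound 2. None of these supplies a size or direction to carry forward, so weak inhibition close to the limit is expected, and the expected change is a number no higher from compound 3 to compound 4 (the limit leaves the size open). The estimated value for compound 4 is 50000 nM, within an expected range of 10000 nM to 150000 nM.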

Compound 4, half-maximal inhibitory concentration: 37600 nM
Estimate against measurement, compound 4: 1.3-fold (0.12 log units) above, within the range that was stated.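

In this assay, compound 4, with the longest chain shown, gives the first result here that is a number and not a limit. Within the data shown here, its longer chain gives an at least 3.9-fold lower number from compound 2 to compound 4 (0.60 log units; beyond the scatter), the only new step that clears the scatter, while the other two are an at least 1.3-fold lower number from compound 3 to compound 4 (0.12 log units; that floor lies within the scatter) and an at least 1.3-fold lower number from compound 1 to compound 4 (0.12 log units; that floor lies within the scatter). These sizes are only floors, because the shorter-chain compounds stay at limits: the limit of > 50000 nM in this assay, at which 2 of the 4 values shown sit.

On these data alone, whether a still longer chain would lower the number further remains open. So does the effect of a carboxylic acid or an amine in place of the hydroxycarbamoyl end.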